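A few compounds are considered here, and "the series" means these few. Any claim that something is new, unique, unknown or untested is made for them only; others in the source may bear on it.

Measured compounds so far:
compound 1, `C#CCNC(=O)CN(Cc1ccccc1)Cc1c(-c2ccc(NC(=O)NCC)cc2)nc2n(Cc3c(F)cccc3F)cc(C(=O)OCC)c(=O)n12`, 1000 nM
compound 2, `C#CCNC(=O)Nc1ccc(-c2nc3n(Cc4c(F)cccc4F)cc(C(=O)OCC)c(=O)n3c2CN(C)Cc2ccccc2)cc1`, 676 nM
compound 3, `CCNC(=O)Nc1ccc(-c2nc3n(Cc4c(F)cccc4F)cc(C(=O)NCc4cn(CCN=[N+]=[N-])nn4)c(=O)n3c2CN(C)Cc2ccccc2)cc1`, < 10000 nM

All three values come from a functional assay on CHO cells for antagonist activity at Gonadotropin-releasing hormone receptor (Homo sapiens), read by a luciferase reporter, with a stated time of 30 min; on this read-out higher numbers stand for weaker inhibition and lower numbers for stronger inhibition. For compound 3 the result is only a limit of the assay, (the limit of < 10000 nM in this assay, at which 1 of the 3 values shown sits), so its true place on the scale is not fixed. Compound 4, `CCNC(=O)Nc1ccc(-c2nc3n(Cc4c(F)cccc4F)cc(C(=O)OCC)c(=O)n3c2CN(C)Cc2ccccc2)cc1`, has not been measured yet. It differs from compound 3 in one place: ethoxy in place of ((1-(2-azidoethyl)-1H-1,2,3-triazol-4-yl)methyl)amino on a carbonyl carbon. Within the data shown here, no two measured compounds differ in a single place, so no measured step guides this change directly. The same ester and the same amine that compound 4 carries are also present in compound 2, and compound 2 gives 676 nM. On that basis compound 4 is expected to reach stronger inhibition, a lower number. For compound 4 the expected step is estimated as a step that the limit leaves unreadable from compound 3 to compound 4. The estimate for compound 4 in this assay is 600 nM, ranging from 250 nM to 1500 nM.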

Compound 4, half-maximal inhibitory concentration: 70.8 nM
For compound 4 the middle estimate is 8.5-fold (0.93 log units) above the measured one, outside the stated range (below it).
By their numbers in this assay, from the lowest: compound 4; then compounds 2 and 1 (each within the scatter of the next).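

In this assay, methyl in place of ethynyl on a saturated chain carbon bound to an amide-type nitrogen gives a 9.5-fold lower number from compound 2 to compound 4 (0.98 log units; beyond the scatter), and hydrogen in place of propargylcarbamoyl on a saturated chain carbon bound to an amine nitrogen gives a 14-fold lower number from compound 1 to compound 4 (1.15 log units; beyond the scatter). Both steps remove an alkyne-bearing group, and both lower the number. The step from compound 3 cannot be read, since compound 3 has only a limit of the assay: the limit of < 10000 nM in this assay, at which 1 of the 4 values shown sits.

Open, going by these compounds, is how a carboxylic acid or a simple methyl amide on that carbonyl carbon would read. Also open, on these data alone, is whether the triazole ring or the azido group of compound 3 matters more.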